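Chloro to Methylsulfanyl on the Shared Core

This account rests on a few compounds, and the source may have more. Where it says the series, first, only, none or still open, it means among the compounds named here.

Compound 3 `Nc1ncnc2c1nc(Cl)n2Cc1ccccc1` is known in a functional assay (spleen, spleen) for activation, with Mus musculus as the target (on this read-out higher numbers stand for an effect only at larger amounts of compound and lower numbers for an effect already at smaller amounts), only as a limit: in that assay compound 3 gives > 10 uM, so no number is fixed for it. Compound 1 `COc1ccc(Cn2c(O)nc3c(N)ncnc32)cc1` gives 10 uM in this assay, and compound 2 `Nc1ncnc2c1nc(O)n2Cc1ccc(Cl)cc1` gives 10 uM; the step of no change at the digits printed from compound 1 to compound 2 (within the scatter) stays within the scatter. Compound 4 `CSc1nc2c(N)ncnc2n1Cc1ccccc1` differs from compound 3 in one place: methylsulfanyl in place of chloro on an aromatic carbon. Among the measured compounds shown here, the only measured step changes a different part of the structure, so it says little about this change. No step beyond the scatter is expected, and with the limit of > 10 uM in this assay, at which 1 of the 3 values shown sits, already present in the series, the result may again be a limit. Compound 4 is estimated at 15 uM, between 5 uM and 50 uM, which means the expected step that the limit leaves unreadable from compound 3 to compound 4.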

Compound 4, minimum effective concentration: > 10 uM
Compound 4: no number, only a limit (the forecaster's own chance of this, stated with the estimate: 60%); the middle value lies beyond the limit too.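

Compound 3 and compound 4 are both known only as limits, so no step can be read between them. The compounds shown leave open how far beyond its limit each compound lies, and whether chloro or methylsulfanyl gives an effect at smaller amounts.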